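A Single Ring Stereocentre Flip in a Sulfoxide Series

A few compounds are considered here, and "the series" means these few. Any claim that something is new, unique, unknown or untested is made for them only; others in the source may bear on it.

Compound 1 `C[C@H]1O[C@@H]([C@@H]2CCCN2C)C[S@+]1[O-]` and compound 2 `C[C@@H]1O[C@H]([C@H]2CCCN2C)C[S@+]1[O-]` share every atom and bond and differ only in the drawn configuration at three ring carbons. In an assay on CHO cells for binding affinity to muscarinic acetylcholine receptor M5 (Homo sapiens) (a higher number here means a weaker inhibitor, a lower number a stronger inhibitor), compound 1 gives only a limit, < 100000 nM. Compound 2 likewise gives only a limit in this assay, < 100000 nM. The step that the two limits leave unreadable from compound 1 to compound 2 cannot be read because of the limit of < 100000 nM in this assay, at which 2 of the 2 values shown sit. Compound 3 `C[C@@H]1O[C@H]([C@@H]2CCCN2C)C[S@+]1[O-]` differs from compound 2 by the two compounds have the same atoms and bonds and differ only in configuration as drawn: 1 of 4 stereo elements differ; a stereocentre at a saturated ring carbon is drawn R in compound 2 and S in compound 3. Going by the values given here, no measured step bears on this single inversion, so no direction can be foreseen, and the step that the limit leaves unreadable from compound 2 to compound 3 is expected to stay within scatter. For compound 3 a value of 30000 nM is expected, in the range 3000 nM to 100000 nM.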

Compound 3, inhibition constant: < 100000 nM
Compound 3 ended at the assay's limit (the forecaster's own chance of this, stated with the estimate: 70%); the middle value does not contradict the limit.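

No step between compound 1, compound 2 and compound 3 can be read in this assay, because all three give only a limit: the limit of < 100000 nM in this assay, at which 3 of the 3 values shown sit.

From the compounds shown here alone, whether the drawn configuration affects the result in this assay stays open.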